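Working notes: phenyl to propyl, compound 2 to compound 3

This account rests on a few compounds, and the source may have more. Where it says the series, first, only, none or still open, it means among the compounds named here.

Measured so far:
compound 1 `CCC1Oc2c(Cl)cccc2N(O)C1=O`, in an ADME assay on the whole organism for inhibition, with Oryza sativa as the target, with a stated time of 7 days (a lower number here means a stronger inhibitor, a higher number a weaker inhibitor), compound 1 gives 305000 nM
compound 2 `O=C1C(c2ccccc2)Oc2ccc(F)cc2N1O`, in this assay compound 2 gives 1240000 nM

Compound 2 stands highest of the two numbers; compound 1 is its nearest neighbour, and the gap between them lies beyond the scatter. Compound 3 `CCCC1Oc2ccc(F)cc2N(O)C1=O` is not yet measured. It differs from compound 2 by propyl in place of phenyl on a saturated ring carbon. Among the measured compounds shown here, no step between measured compounds covers this change, so the expected size is uncertain; a lower number than compound 2 shows is expected, since compound 1 gives 305000 nM. Compound 3 is estimated at 450000 nM, range 150000 nM to 1300000 nM, an expected step of a 2.8-fold lower number from compound 2 to compound 3 (0.44 log units; beyond the scatter).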

Compound 3, half-maximal inhibitory concentration: 337000 nM
The estimate for compound 3 lay 1.3-fold (0.13 log units) above the measured number; measured number inside the range.
By their numbers in this assay, from the lowest: compounds 1 and 3 (each within the scatter of the next); then compound 2.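

In this assay, the saturated ring carbon next to the ring oxygen proves sensitive to its substituent: propyl in place of phenyl gives a 3.7-fold lower number from compound 2 to compound 3 (0.57 log units; beyond the scatter) on an otherwise unchanged core. An aromatic ring at this position is therefore not required for inhibition, and the open-chain propyl is the stronger inhibitor of this pair. No available data bear on the reason for this step.

As far as these compounds go, whether a longer chain, a branched chain such as isopropyl, or an amine would lower the number further remains open. From the compounds shown here alone, it is also open whether this step would hold on a core with different ring substitution.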